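Swapping a cyanopyridine for a chlorophenyl on a weak hit

The source may report more compounds than this note shows. Statements on the series, on what has been measured and on what is new or still open speak of the compounds shown alone.

Measured so far:
compound 1, `Cc1c(-c2cc(Cl)cc(Cl)c2)c(C(=O)O)nn1-c1nc(-c2cnn(C)c2)c(SC(C)C)s1` – "not active" (no number reported)
compound 2, `Cc1nn(-c2nc(-c3ccc(Cl)c(Cl)c3)c(SC(C)C)s2)c(C(=O)O)c1-c1cncc(C#N)c1` – 20000 nM
compound 3, `COC(=O)c1c(Cc2ccccc2[N+](=O)[O-])c(C)nn1-c1nc(-c2ccc(Cl)c(Cl)c2)c(SC(C)C)s1` – 93000 nM

All three compounds were tested in a functional assay on BJAB cells (Homo sapiens) for antiproliferative activity, with a stated time of 4 days; on this read-out lower numbers stand for an effect already at smaller amounts and higher numbers for an effect only at larger amounts of compound. Compound 1 gave no number at all, being reported simply as "not active" (no number reported). Of the two compounds that did give numbers, compound 2 has the lower one, and compound 3 sits at a higher number; the gap between these two lies beyond the usual scatter of repeated measurements, so compound 2 is the more potent of the pair. Still, its number is far from small.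

Compound 4, `Cc1nn(-c2nc(-c3ccc(Cl)c(Cl)c3)c(SC(C)C)s2)c(C(=O)O)c1-c1ccccc1Cl`, is the next step. Compared with compound 2 it carries 2-chlorophenyl in place of 5-cyanopyridin-3-yl on an aromatic carbon. Among the measured compounds shown here, no pair of measured compounds differing in only this way exists, so there is no measured step to lean on. The expectation for the step from compound 2 to compound 4 is therefore a modest change at most, a 1.5-fold higher number from compound 2 to compound 4 (0.18 log units; within the scatter), possibly no larger than the scatter. Compound 4 is estimated to give 30000 nM in this assay, within a range from 8000 nM to 120000 nM.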

Compound 4, half-maximal effective concentration: 13100 nM
For compound 4 the middle estimate is 2.3-fold (0.36 log units) above the measured one; the measured number falls inside the stated range.
By their numbers in this assay, from the lowest: compounds 4 and 2 (each within the scatter of the next); then compound 3.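

In this assay, putting 2-chlorophenyl in place of 5-cyanopyridin-3-yl on this aromatic carbon gives a 1.5-fold lower number from compound 2 to compound 4 (0.18 log units; within the scatter). This is the only pair shown that differs solely at this place, and it shows that a ring of carbon only, bearing a chlorine, can stand in for a pyridine ring bearing a nitrile without a change beyond the scatter, although both numbers remain large. Nothing at hand explains this result.

On these data alone, it remains open whether any group at this place can bring the number down beyond the scatter, such as a phenyl ring carrying an amine or a longer alkyl chain. Also open, as far as these compounds go, is how the number would respond to an amide in place of the carboxy group while 2-chlorophenyl stays.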